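From Dimethyl to Bromo-Hydroxy on a Shared Core

The source may report more compounds than this note shows. Statements on the series, on what has been measured and on what is new or still open speak of the compounds shown alone.

Three compounds share one core and differ only in the aryl group on a double-bonded chain carbon bound to a double-bonded ring carbon. In an assay on HeLa cells for inhibition of Kinesin-like protein KIF15 (Homo sapiens), read by microscopy, with stated times of 2 s and 20 s, tested at 750 nM (on this read-out higher numbers stand for more inhibition at the one concentration tested (going by the name of the read-out) and lower numbers for less inhibition), compound 1 `O=C1Nc2ccc(C(=O)c3ccco3)cc2/C1=C/c1cc(F)c(O)c(F)c1` gives 21%, compound 2 `O=C1Nc2ccc(C(=O)c3ccco3)cc2/C1=C/c1cc(I)c(O)c(I)c1` gives 26%, and compound 3 `Cc1cc(/C=C2\C(=O)Nc3ccc(C(=O)c4ccco4)cc32)cc(C)c1O` gives 9%, the lowest of the three. Compound 4 `O=C1Nc2ccc(C(=O)c3ccco3)cc2/C1=C/c1ccc(Br)c(O)c1` is not yet measured; the change from compound 3 is 4-bromo-3-hydroxyphenyl in place of 4-hydroxy-3,5-dimethylphenyl on a double-bonded chain carbon bound to a double-bonded ring carbon. Among the measured compounds shown here, two measured steps bear on it: a number 12 percentage points lower from compound 1 to compound 3 (beyond the scatter) and a number 17 percentage points lower from compound 2 to compound 3 (beyond the scatter), both showing that rings with halogens gave higher numbers than the dimethyl ring. Compound 4 carries one bromine, so a modest rise in this assay is expected, a number 9 percentage points higher from compound 3 to compound 4 (within the scatter). Compound 4 is therefore estimated at 18%, between 5% and 32%.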

Compound 4, a percentage reported as inhibition, at one concentration (the size of the read-out at that concentration, not a potency): -5.6%
Beside the measured number, compound 4's estimate is 23.6 percentage points above it; measured number below the stated range.
By their numbers in this assay, from the lowest: compound 4; then compound 3; then compounds 1 and 2 (each within the scatter of the next).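

In this assay, a halogen on the ring does not by itself raise the number at this position: the single-bromine ring falls below the dimethyl ring, a number 14.6 percentage points lower from compound 3 to compound 4 (beyond the scatter), and further below the two dihalogen rings, a number 26.6 percentage points lower from compound 1 to compound 4 (beyond the scatter) and a number 31.6 percentage points lower from compound 2 to compound 4 (beyond the scatter). So the arrangement of groups on this aryl ring counts, not only whether a halogen is present. Nothing measured here explains the fall.

The 4-bromo-3-hydroxyphenyl group differs from the other rings in both hydroxy place and substituent count, so these two changes cannot be separated. Going by these compounds, how an amine or a carboxylic acid in place of the hydroxy group would read also stays open.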